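The source may hold more compounds than are shown below. What is called first, only, known or untested is meant among the compounds shown, and "the series" means these compounds.

Three compounds that differ in one place on a shared core have been tested in a functional assay on HeLa cells (Homo sapiens) for inhibition, read by CCK-8 assay, with a stated time of 48 h; a lower number here means a stronger inhibitor, a higher number a weaker inhibitor. Compound 1 `COc1cc(-c2ccnc3cc(-c4ccc(C)cc4)nn23)cc(OC)c1OC` carries a methyl there and gives 21 nM, compound 2 `COc1cc(-c2ccnc3cc(-c4ccccc4)nn23)cc(OC)c1OC` carries hydrogen and gives 458 nM, and compound 3 `C=Cc1ccc(-c2cc3nccc(-c4cc(OC)c(OC)c(OC)c4)n3n2)cc1` carries vinyl and gives 882 nM. Compound 3 thus sits level with compound 2 within the scatter and far from compound 1. Losing the methyl costs much: the data show a 22-fold higher number from compound 1 to compound 2 (1.34 log units; beyond the scatter) and a 42-fold higher number from compound 1 to compound 3 (1.62 log units; beyond the scatter), both large, whereas a 1.9-fold higher number from compound 2 to compound 3 (0.28 log units; within the scatter) is within the scatter.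

Compound 4 `COc1cc(-c2ccnc3cc(-c4ccc(C(C)=O)cc4)nn23)cc(OC)c1OC` has acetyl in place of vinyl on an aromatic carbon, para to a large group: acetyl in place of vinyl on an aromatic carbon. Going by the values given here, no measured step makes this exact swap, so the guide is indirect. Neither non-methyl group so far has come close to compound 1, so compound 4 is expected to lie with compound 2 and compound 3, with no change beyond the scatter in this assay. The expected step is a 1.5-fold lower number from compound 3 to compound 4 (0.17 log units; within the scatter). For compound 4 the estimated value is 600 nM, with an expected range of 150 nM to 2000 nM.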

Compound 4, half-maximal inhibitory concentration: 1810 nM
Compound 4: the middle estimate sits 3.0-fold (0.48 log units) below what was measured; low and high end bracket the measured number.
By their numbers in this assay, from the lowest: compound 1; then compounds 2 and 3 (each within the scatter of the next); then compound 4.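

In this assay, acetyl stands apart from the other groups that replace methyl: a 2.1-fold higher number from compound 3 to compound 4 (0.31 log units; beyond the scatter) and a 4.0-fold higher number from compound 2 to compound 4 (0.60 log units; beyond the scatter) are both modest but beyond the scatter, whereas hydrogen and vinyl could not be separated. This position therefore does more than divide methyl from everything else, and an 86-fold higher number from compound 1 to compound 4 (1.94 log units; beyond the scatter) shows how far 4-acetylphenyl lies from the methyl-bearing compound. Nothing measured here explains why the number rises when vinyl gives way to acetyl, a swap that adds an oxygen and a hydrogen-bond acceptor.

The compounds shown leave open whether ethyl, methoxy or a chlorine atom on this carbon would come near compound 1 or fall with the others. They also leave open where an amine or a carboxylic acid would land in this order.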